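The compounds below may be only part of what the source reports. "The series", "measured", "known", "first", "only" and "open" are said of these compounds alone.

Among the compounds with values here, in a functional assay on the whole organism with Mus musculus as the target (on this read-out lower numbers stand for an effect already at smaller amounts and higher numbers for an effect only at larger amounts of compound), compound 2 `NC(=O)/C=C1\CCc2ccc(F)cc21` gives 56 mg/kg and compound 1 `O=C(/C=C1\CCc2c(F)cc(F)cc21)NC1CC1` gives 62 mg/kg, so compound 2 stands level with the only other measured compound, within the usual scatter. Compound 3 `O=C(/C=C1\CCc2ccc(F)cc21)NC1CC1` has cyclopropyl in place of hydrogen on an amide-type nitrogen of compound 2: cyclopropyl in place of hydrogen on an amide-type nitrogen. Within the data shown here, no measured pair isolates this change. Compound 1 also carries cyclopropyl on its amide-type nitrogen and gives 62 mg/kg, so no step beyond the scatter is expected in this assay, in either direction. The estimated step of a 1.1-fold higher number from compound 2 to compound 3 (0.03 log units; within the scatter) stays within the scatter. The expected value for compound 3 is 60 mg/kg, with an estimated range of 28 mg/kg to 125 mg/kg.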

Compound 3, dose for half-maximal effect: 66 mg/kg
Compound 3: middle estimate off by 1.1-fold (0.04 log units), on the low side; the range from low to high includes it.
By their numbers in this assay, from the lowest: compounds 2, 1 and 3 (each within the scatter of the next).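

In this assay, cyclopropyl in place of hydrogen on an amide-type nitrogen now has its own measured pair, and a 1.2-fold higher number from compound 2 to compound 3 (0.07 log units; within the scatter) stays within the scatter. Hydrogen in place of fluoro on an aromatic carbon can also be read directly, with a 1.1-fold higher number from compound 1 to compound 3 (0.03 log units; within the scatter) likewise within the scatter. No available measurement accounts for either result. Open, as far as these compounds go, is whether a longer chain, a phenyl ring or a chain ending in an amine on the amide-type nitrogen would shift the number beyond the scatter.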